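Halogen swap on the anilino ring of an acrylamide quinazoline series

The source may hold more compounds than are shown below. What is called first, only, known or untested is meant among the compounds shown, and "the series" means these compounds.

For the measured compounds named here, compound 2 `C=CC(=O)Nc1cccc(NC(=O)CSc2nc(Nc3ccccc3Cl)c3ccccc3n2)c1` gives 10000 nM in a functional assay on NCI-H1975 cells (Homo sapiens) for inhibition, read by MTT assay, with a stated time of 72 h (on this read-out lower numbers stand for stronger inhibition and higher numbers for weaker inhibition), the highest of the two numbers measured so far; compound 1 `O=C(CSc1nc(Nc2ccccc2)c2ccccc2n1)Nc1cccc(F)c1` gives 6790 nM, and the two numbers lie within the scatter of each other, so no order between them can be read. Compound 3 `C=CC(=O)Nc1cccc(NC(=O)CSc2nc(Nc3ccc(F)cc3)c3ccccc3n2)c1` is not yet measured and differs from compound 2 by 4-fluorophenyl in place of 2-chlorophenyl on a nitrogen on an aromatic ring. Going by the values given here, no step between measured compounds is available for this change, so nothing beyond the scatter is expected from compound 2 to compound 3, with at most a slight lowering. Compound 3 is estimated at 7000 nM, within 2500 nM to 20000 nM, a step of a 1.4-fold lower number from compound 2 to compound 3 (0.15 log units; within the scatter).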

Compound 3, half-maximal inhibitory concentration: 4430 nM
Beside the measured number, compound 3's estimate is 1.6-fold (0.20 log units) above it, and the stated range covers the measured number.
By their numbers in this assay, from the lowest: compounds 3, 1 and 2 (each within the scatter of the next, the first and the last beyond it).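

The step of a 2.3-fold lower number from compound 2 to compound 3 (0.35 log units; beyond the scatter) in this assay shows that this position, on a nitrogen on an aromatic ring, can move the number beyond the scatter, though only modestly. The earlier compounds shown here offered no step between measured compounds to show this. The change replaces the halogen and its place on the phenyl ring together, so the two cannot be told apart.

From the compounds shown here alone, whether 2-fluorophenyl, 4-chlorophenyl or a methoxy-bearing phenyl would move the number further remains open. No measured evidence here bears on what lies behind the step.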